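A Third Methoxy on the Aryl Ring of Compound 3

The compounds below may be only part of what the source reports. "The series", "measured", "known", "first", "only" and "open" are said of these compounds alone.

Compound 1, `CN(C)CCn1cnnc1-c1cc(Oc2ccc(NC(=O)N/N=C/c3cccc(O)c3)cc2F)ccn1`: in a functional assay on A549 cells (Homo sapiens) for cytotoxicity, read by MTT assay, with a stated time of 72 h (on this read-out lower numbers stand for stronger inhibition and higher numbers for weaker inhibition), compound 1 reaches only the assay limit of > 100000 nM.
Compound 2, `CN(C)CCn1cnnc1-c1cc(Oc2ccc(NC(=O)N/N=C/c3ccc(F)cc3Cl)cc2F)ccn1`: in this assay compound 2 gives 1120 nM.
Compound 3, `COc1ccc(/C=N/NC(=O)Nc2ccc(Oc3ccnc(-c4nncn4CCN(C)C)c3)c(F)c2)c(OC)c1`: in this assay compound 3 gives 2820 nM.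

Of the two numbers shown, compound 3 stands highest; the step of a 2.5-fold higher number from compound 2 to compound 3 (0.40 log units; beyond the scatter) lies beyond the scatter. Compound 1 sits at a limit, (the limit of > 100000 nM in this assay, at which 1 of the 3 values shown sits).

Compound 4, `COc1ccc(/C=N/NC(=O)Nc2ccc(Oc3ccnc(-c4nncn4CCN(C)C)c3)c(F)c2)c(OC)c1OC`, differs from compound 3 by methoxy in place of hydrogen on an aromatic carbon. For the measured compounds named here, no measured step touches this position: the steps of an at least 89-fold lower number from compound 1 to compound 2 (1.95 log units; beyond the scatter) and an at least 35-fold lower number from compound 1 to compound 3 (1.54 log units; beyond the scatter) exchange the whole aryl group, and a 2.5-fold higher number from compound 2 to compound 3 (0.40 log units; beyond the scatter) does the same. They show that the aryl group matters, but give no direction for adding one methoxy. Compound 4 is therefore expected to change little, a 1.1-fold higher number from compound 3 to compound 4 (0.03 log units; within the scatter), within the scatter. The estimate for compound 4 is 3000 nM, between 800 nM and 12000 nM.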

Compound 4, half-maximal inhibitory concentration: 6680 nM
Compound 4: middle estimate off by 2.2-fold (0.35 log units), on the low side, and the stated range covers the measured number.
By their numbers in this assay, from the lowest: compound 2; then compound 3; then compound 4. At a limit, above all of these: compound 1.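

Methoxy in place of hydrogen, ortho to two methoxy groups, is the first change read at this position alone: this assay shows a 2.4-fold higher number from compound 3 to compound 4 (0.37 log units; beyond the scatter) on this single addition. The 2,3,4-trimethoxyphenyl group also falls short of 2-chloro-4-fluorophenyl, with a 6.0-fold higher number from compound 2 to compound 4 (0.78 log units; beyond the scatter) as the step, while an at least 14-fold lower number from compound 1 to compound 4 (1.17 log units; beyond the scatter) still separates it from 3-hydroxyphenyl. That last step rests on a limit for compound 1: (the limit of > 100000 nM in this assay, at which 1 of the 4 values shown sits). As far as these compounds go, whether hydroxy or an amine at this position would move the number in the same direction remains open.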